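The compounds below may be only part of what the source reports. "The series", "measured", "known", "first", "only" and "open" are said of these compounds alone.

Working notes on the series.

Compound 1 `COc1cc2c(Oc3ccc(NC(=O)c4nn(-c5ccccc5Br)c(=O)c5ccccc45)cc3F)ccnc2cc1OCCCN1CCCC1` gives 850 nM in a functional assay on HT-29 cells (Homo sapiens) for cytotoxicity, read by MTT assay, with a stated time of 72 h; on this read-out higher numbers stand for weaker inhibition and lower numbers for stronger inhibition. Compound 2 `COc1cc2c(Oc3ccc(NC(=O)c4nn(-c5ccc([N+](=O)[O-])cc5)c(=O)c5ccccc45)cc3F)ccnc2cc1OCCCN1CCCC1` gives 1760 nM in this assay; the difference from compound 1 is 4-nitrophenyl in place of 2-bromophenyl on an aromatic nitrogen, and the step is a 2.1-fold higher number from compound 1 to compound 2 (0.32 log units; beyond the scatter). Compound 3 `COc1cc2c(Oc3ccc(NC(=O)c4nn(-c5ccccc5Br)c(=O)c5ccccc45)cc3F)ccnc2cc1OCCCN1CCC(C)CC1` gives 950 nM in this assay; its difference from compound 1 is 4-methylpiperidin-1-yl in place of pyrrolidin-1-yl on a saturated chain carbon, three bonds along the chain from an oxygen on an aromatic ring, and the step is a 1.1-fold higher number from compound 1 to compound 3 (0.05 log units; within the scatter). The values of compound 2 and compound 3 lie within the scatter of each other.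

Compound 4 `COc1cc2c(Oc3ccc(NC(=O)c4nn(-c5ccc([N+](=O)[O-])cc5)c(=O)c5ccccc45)cc3F)ccnc2cc1OCCCN1CCC(C)CC1` has not been measured in this assay. Its difference from compound 3 is 4-nitrophenyl in place of 2-bromophenyl on an aromatic nitrogen, the same change as that from compound 1 to compound 2: the place around the change reads the same word for word in both cases, and the two cores differ only by 4-methylpiperidin-1-yl in place of pyrrolidin-1-yl on a saturated chain carbon, three bonds along the chain from an oxygen on an aromatic ring, a difference that made a step within the scatter. On that basis the step from compound 3 to compound 4 is expected to be close in size to the earlier one, about a 2.1-fold higher number from compound 3 to compound 4 (0.31 log units; beyond the scatter). For compound 4 the estimated value in this assay is therefore 1950 nM, with a likely range from 1000 nM to 3800 nM.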

Compound 4, half-maximal inhibitory concentration: 2450 nM
Compound 4: the middle estimate sits 1.3-fold (0.10 log units) below what was measured; the range from low to high includes it.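

In this assay, 4-nitrophenyl in place of 2-bromophenyl gives a 2.6-fold higher number from compound 3 to compound 4 (0.41 log units; beyond the scatter), and this step agrees with the one on the core of compound 1: the same change on two cores in this assay, a 2.1-fold higher number (0.32 log units; beyond the scatter) from compound 1 to compound 2 and a 2.6-fold higher number (0.41 log units; beyond the scatter) from compound 3 to compound 4, 1.2-fold (0.10 log units) apart, within the scatter of two such steps. The other change, 4-methylpiperidin-1-yl in place of pyrrolidin-1-yl, gives a 1.4-fold higher number from compound 2 to compound 4 (0.14 log units; within the scatter), and it too carries over: the same change on two cores in this assay, a 1.1-fold higher number (0.05 log units; within the scatter) from compound 1 to compound 3 and a 1.4-fold higher number (0.14 log units; within the scatter) from compound 2 to compound 4, 1.2-fold (0.10 log units) apart, within the scatter of two such steps. Within this set of compounds, each change therefore behaves the same on both cores, but this rests on a single square of compounds in one assay and does not show that either step would hold on other cores, nor does it explain why the steps have these sizes.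

The compounds shown leave open how a phenyl or 4-bromophenyl group on the aromatic nitrogen would compare with 2-bromophenyl and 4-nitrophenyl. On these data alone, it also remains open whether a morpholin-4-yl or dimethylamino group at the end of the chain would leave the values as close as the two amines here do.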